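A few compounds are considered here, and "the series" means these few. Any claim that something is new, unique, unknown or untested is made for them only; others in the source may bear on it.

Measured in a functional assay on FaDu cells (Homo sapiens) for cytotoxicity, read by MTT assay, with a stated time of 72 h; a higher number here means that more compound is tolerated, a lower number that less compound is tolerated:
- compound 1 `CCn1cc(C(=O)C(=O)Nc2ccc(OC)nc2)c2ccccc21`: 219 nM
- compound 2 `COc1ccc2c(c1)c(C(=O)C(=O)Nc1ccc(OC)nc1)cn2C(C)C`: > 10000 nM (a limit of the assay, not a number)
- compound 3 `COc1ccc(NC(=O)C(=O)c2cn(C(C)C)c3ccccc23)cn1`: 85 nM

Within the data shown here, compound 3 gives 85 nM, the lowest number measured so far, so it is the compound of which the least is tolerated here. The next step leads to compound 4 `CC(C)n1cc(C(=O)C(=O)Nc2ccc(C(F)(F)F)nc2)c2ccccc21`, where trifluoromethyl replaces methoxy on an aromatic carbon of a six-membered aromatic ring with 1 nitrogen, next to the ring nitrogen: trifluoromethyl in place of methoxy on an aromatic carbon.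

Among the measured compounds shown here, no measured step touches this place, so the evidence is only indirect. Changing a saturated chain gave a modest shift, a 2.6-fold lower number from compound 1 to compound 3 (0.41 log units; beyond the scatter). Replacing a methoxy elsewhere in the molecule gave a large one, an at least 110-fold lower number from compound 2 to compound 3 (2.07 log units; beyond the scatter). A single change can therefore move this assay a long way, though neither step fixes the direction here.

A moderate rise is expected, with wide uncertainty: a 2.9-fold higher number from compound 3 to compound 4 (0.47 log units; beyond the scatter). The estimate for compound 4 is 250 nM, with an expected range from 50 nM to 2000 nM.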

Compound 4, concentration lethal to 50% of the cells: > 10000 nM
Compound 4: no number, only a limit; the forecaster's own chance of this, stated with the estimate: 10%; middle value at least 40-fold (1.60 log units) from the limit.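

This position turns out to be highly sensitive: on the aromatic carbon next to the ring nitrogen, trifluoromethyl in place of methoxy gives an at least 110-fold higher number from compound 3 to compound 4 (2.07 log units; beyond the scatter) in this assay. The earlier steps changed other places, so this is the first sign that a single swap on this ring can also carry the reading from the lowest number shown to the limit of the assay, which is not a number and so hides the true size of the step. Compound 2 and compound 4 each differ from compound 3 in one separate place, and both end at the same limit: the limit of > 10000 nM in this assay, at which 2 of the 4 values shown sit.

With only one replacement shown here, it stays open whether methoxy is specially needed or trifluoromethyl alone causes the loss. An amine or a longer chain such as ethoxy at this carbon would help to tell these two readings apart.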